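The source may report more compounds than this note shows. Statements on the series, on what has been measured and on what is new or still open speak of the compounds shown alone.

Compound 1 `CCC(COc1ccc(Cl)c(Cl)c1)OC(=O)NCc1ccccc1` and compound 2 `CCC(CN(C(C)=O)c1cccc(Cl)c1)OC(=O)NCc1ccccc1` share a common core. In an assay for inhibition of zeta-carotene desaturase, chloroplastic/chromoplastic (Capsicum annuum), using a Dixon plot, with a stated time of 8 h (on this read-out higher numbers stand for weaker inhibition and lower numbers for stronger inhibition), compound 1 reaches only a limit of the assay, > 100000 nM. Compound 2 in this assay likewise gives only a limit, > 100000 nM. Compound 2 therefore stands at the limit described by the limit of > 100000 nM in this assay, at which 2 of the 2 values shown sit, with no number of its own. Compound 3 `CCC(CN(C(=O)c1ccccc1)c1cccc(Cl)c1)OC(=O)NCc1ccccc1` differs from compound 2 by phenyl in place of methyl on a carbonyl carbon. Among the measured compounds shown here, no step between measured compounds exists here, so no size or direction can be read from the numbers. The expected step of a number no higher from compound 2 to compound 3 (the limit leaves the size open) is none beyond the scatter. Compound 3 is estimated at 100000 nM, from 30000 nM to 300000 nM.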

Compound 3, half-maximal inhibitory concentration: > 100000 nM
Compound 3 ended at the assay's limit; the forecaster's own chance of this, stated with the estimate: 80%; the middle value lies on the limit itself.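

Compound 2 and compound 3 both end at a limit and not at a number, so no step between them can be read: the limit of > 100000 nM in this assay, at which 3 of the 3 values shown sit.

The compounds shown leave open whether acetyl and benzoyl differ at all, and which change to the shared core would give a measured number in this assay.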